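Cytotoxicity outlook for compound 4 in the series

The compounds below may be only part of what the source reports. "The series", "measured", "known", "first", "only" and "open" are said of these compounds alone.

Compound 1 `C[C@]1(CN2CCc3nc(C4CC4)ccc3C2)Cn2cc([N+](=O)[O-])nc2O1` has no result in an ADME assay on Vero cells (Chlorocebus sabaeus) for cytotoxicity, read by MTT assay, with a stated time of 72 h; on this read-out higher numbers stand for lower toxicity in this test and lower numbers for higher toxicity in this test ("not determined" (no result reported)). In this assay compound 2 `C[C@]1(CN2CCc3nc(-c4ccc(F)cc4F)ccc3C2)Cn2cc([N+](=O)[O-])nc2O1` gives 12.5 ug/mL. For compound 3 `C[C@]1(CN2CCc3nc(-c4cc(F)cc(F)c4)ccc3C2)Cn2cc([N+](=O)[O-])nc2O1` the result is a limit of the assay, > 32 ug/mL. Compound 3 therefore sits at the limit described by the limit of > 32 ug/mL in this assay, at which 1 of the 3 values shown sits, and one further entry in the series carries no single number. For the measured compounds named here, the only step with two numbers is an at least 2.5-fold higher number from compound 2 to compound 3 (0.40 log units; beyond the scatter), which shows that the fluorine pattern on the aryl group can move the read-out beyond the scatter.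

Compound 4 `C[C@]1(CN2CCc3nc(-c4cc(Cl)ccc4F)ccc3C2)Cn2cc([N+](=O)[O-])nc2O1` differs from compound 3 by 5-chloro-2-fluorophenyl in place of 3,5-difluorophenyl on an aromatic carbon. Going by the values given here, no measured step carries a chlorine on this aryl group, so the direction of this change is not fixed by the data. As compound 3 already stands at the limit, the expected outcome is a step of an at least 1.1-fold lower number from compound 3 to compound 4 (0.05 log units; that floor lies within the scatter), that is, no move beyond the scatter or a modest fall. Compound 4 is estimated at 28 ug/mL, within the range 12 ug/mL to 64 ug/mL.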

Compound 4, half-maximal cytotoxic concentration: > 32 ug/mL
Compound 4 was reported as a limit; the forecaster's own chance of this, stated with the estimate: 50%; middle value at least 1.1-fold (0.05 log units) from the limit.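

In this assay, the aromatic carbon next to the ring nitrogen takes 5-chloro-2-fluorophenyl in place of 2,4-difluorophenyl with an at least 2.5-fold higher number from compound 2 to compound 4 (0.40 log units; beyond the scatter), so a second aryl group, this one carrying chlorine, now stands apart from the 2,4-difluorophenyl result. The step between compound 3 and compound 4 cannot be read, since both results are limits, and no order can be given for these two. Results at a limit now make up a larger share of the series: the limit of > 32 ug/mL in this assay, at which 2 of the 4 values shown sit.

On these data alone, how far the true values of compound 3 and compound 4 lie from their limits stays open, so the two aryl groups cannot be ranked. Also open, as far as these compounds go, is whether a phenyl group carrying an amine or a carboxylic acid in place of the halogens would stay at this limit.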